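The source may report more compounds than this note shows. Statements on the series, on what has been measured and on what is new or still open speak of the compounds shown alone.

Measured compounds and their values:

Compound 1, `COc1cccc(C(=O)N2CCCC(C(=O)Nc3ccc(Cl)cc3)C2)c1`, gives 0%
Compound 2, `O=C(Nc1ccc(Cl)cc1)C1CCCN(C(=O)c2cccc(-c3cnco3)c2)C1`, gives 0%
Compound 3, `COc1cccc(NC(=O)C2CCCN(C(=O)c3cc(C(F)(F)F)cc(C(F)(F)F)c3)C2)c1`, gives 0%

All three were tested in an ADME assay on PC-3 cells (Homo sapiens) for cytotoxicity, read by WST assay, tested at 100 uM (a higher number here means more inhibition at the concentration tested (going by the name of the read-out), a lower number less inhibition), and in each case the read-out sits at the bottom of the scale. Compound 1 and compound 2 share one core and differ in a single place: the change is 1,3-oxazol-5-yl in place of methoxy on an aromatic carbon, and the step it made is no change at the digits printed from compound 1 to compound 2 (within the scatter). Compound 3 carries a different core; how that core differs from the core of compound 1 is not broken down here. Compound 3 stands level with compound 1 and compound 2 in this assay, and the differences between them are within the usual scatter.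

Compound 4, `O=C(Nc1cccc(-c2cnco2)c1)C1CCCN(C(=O)c2cc(C(F)(F)F)cc(C(F)(F)F)c2)C1`, has not yet been measured. It differs from compound 3 by 1,3-oxazol-5-yl in place of methoxy on an aromatic carbon. The place where the change sits is described in the same words as for the change from compound 1 to compound 2, so the two are the same change made on two different cores.

Because the step of no change at the digits printed from compound 1 to compound 2 (within the scatter) showed no movement, and because compound 3 gives 0% on its own core, the expected step from compound 3 to compound 4 in this assay is no change at the digits printed from compound 3 to compound 4 (within the scatter). Compound 4 is therefore expected to give about 0%, with a range from 0% to 10%.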

Compound 4, a percentage reported as inhibition, at one concentration (the size of the read-out at that concentration, not a potency): 9%
For compound 4 the middle estimate is 9 percentage points below the measured one; the range from low to high includes it.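

In this assay, putting 1,3-oxazol-5-yl in place of methoxy on the aromatic carbon of compound 3 gave this result: a number 9 percentage points higher from compound 3 to compound 4 (within the scatter). Set beside the earlier step, the same change behaved alike on the two cores, with no difference between the steps that rises above ordinary assay noise: the same change on two cores in this assay, no change at the digits printed (within the scatter) from compound 1 to compound 2 and a number 9 percentage points higher (within the scatter) from compound 3 to compound 4, 9 percentage points apart, within the scatter of two such steps This shows only that the swap left the read-out within the scatter on both cores; neither step is a clear effect, so the series offers no measurable effect whose transfer from one core to the other could be tested, and two pairs say nothing about further cores.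

The compounds shown leave open whether any group at this place could move the read-out beyond the scatter, for example an amine, a carboxylic acid or a longer chain in place of methoxy or 1,3-oxazol-5-yl. They also leave open whether the swap would behave alike on the two cores at another concentration, or in a test where these compounds give a clearly measurable signal.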